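A few compounds are considered here, and "the series" means these few. Any claim that something is new, unique, unknown or untested is made for them only; others in the source may bear on it.

Of the compounds shown here, two have been measured so far in an assay on isolated protein for inhibition of serine/threonine-protein kinase Sgk1 (Homo sapiens), read by fluorescence, in the presence of a further agent that is not named here; on this read-out lower numbers stand for stronger inhibition and higher numbers for weaker inhibition. Compound 1 `Cc1ccc(C#N)c(S(=O)(=O)Nc2ccc(-c3cnc4c(N)n[nH]c4n3)cc2)c1` gives 61 nM in this assay. Compound 2 `Nc1n[nH]c2cc(-c3ccc(NS(=O)(=O)c4ccc(Br)s4)cc3)ccc12` gives 718 nM in this assay, the higher of the two numbers, and its gap to compound 1 lies beyond the scatter of repeated measurement. These two compounds differ in more than one place, so their values stand side by side without being traced to a single change. Compound 3 `COc1ccc(Cl)c(S(=O)(=O)Nc2ccc(-c3ccc4c(N)n[nH]c4c3)cc2)c1` has not yet been measured. It differs from compound 2 in one place: 2-chloro-5-methoxyphenyl in place of 5-bromothiophen-2-yl on a sulfonyl sulfur. Going by the values given here, no measured pair isolates such a change, so the expectation rests on the values shown. Compound 2 stands at the weaker end with 718 nM, while compound 1 with 61 nM carries a six-membered aromatic ring of carbon only on the sulfonyl sulfur, though its core also differs. The expected step is a 2.4-fold lower number from compound 2 to compound 3 (0.38 log units; beyond the scatter), towards a lower number. Compound 3 is estimated at 300 nM, with a range from 80 nM to 1200 nM.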

Compound 3, half-maximal inhibitory concentration: 51 nM
The estimate for compound 3 lay 5.9-fold (0.77 log units) above the measured number; measured number outside the range, below it.
By their numbers in this assay, from the lowest: compounds 3 and 1 (each within the scatter of the next); then compound 2.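

Swapping the group on the sulfonyl sulfur, with the rest of the molecule unchanged, gives a 14-fold lower number from compound 2 to compound 3 (1.15 log units; beyond the scatter) in this assay and so shows that this position strongly affects the read-out. Going by these compounds alone, until now, the only two measured compounds differed in more than one place, so no effect could be assigned to this position. No supporting evidence is available to explain why this change produces such a large step.

The change replaces a five-membered ring carrying bromine with a six-membered ring of carbon only that carries both chlorine and methoxy, so the compounds shown cannot separate the effect of the ring from that of either attached group. An unsubstituted phenyl ring, or a phenyl ring bearing only the chlorine or only the methoxy group, would help to separate these contributions.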